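The compounds below may be only part of what the source reports. "The series", "measured", "known", "first", "only" and "open" are said of these compounds alone.

Measured so far:
Compound 1, `Cc1nn(-c2ncnc3nc[nH]c23)c2c1C(C(=O)NCc1ccccc1)CC(=O)N2`, in a functional assay on HEK293 cells for agonist activity at G-protein coupled receptor 39 (Homo sapiens), read by scintillation proximity assay and inositol phosphate accumulation, with a stated time of 75 min, in the presence of a further agent that is not named here (a lower number here means that less compound is needed, a higher number that more compound is needed for the effect), gives 5 nM.
Compound 2, `Cc1nn(-c2ncnc3nc[nH]c23)c2c1C(OCc1ccc(C#N)cc1)CC(=O)N2`, gives 4 nM.

Compound 2 shows the lower of the two numbers, yet the step of a 1.3-fold lower number from compound 1 to compound 2 (0.10 log units; within the scatter) lies within the scatter, so the two cannot be ordered. Compound 3, `Cc1nn(-c2ncnc3nc[nH]c23)c2c1C(OCCc1ccccc1)CC(=O)N2`, differs from compound 2 by benzyl in place of 4-cyanophenyl on a saturated chain carbon bound to an oxygen on a saturated carbon. Going by the values given here, the only measured step, a 1.3-fold lower number from compound 1 to compound 2 (0.10 log units; within the scatter), also exchanged the group on a saturated ring carbon and stayed within the scatter, so no step beyond the scatter is expected in this assay here either. Compound 3 is expected to give about 5 nM, between 2 nM and 13 nM, an expected step of a 1.3-fold higher number from compound 2 to compound 3 (0.10 log units; within the scatter).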

Compound 3, half-maximal effective concentration: 3 nM
The estimate for compound 3 lay 1.7-fold (0.22 log units) above the measured number; measured number inside the range.
By their numbers in this assay, from the lowest: compounds 3, 2 and 1 (each within the scatter of the next).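

Phenethyloxy in place of (4-cyanobenzyl)oxy gives a 1.3-fold lower number from compound 2 to compound 3 (0.12 log units; within the scatter) in this assay, so a low number here does not require the nitrile. Against the benzylcarbamoyl group of compound 1, phenethyloxy gives a 1.7-fold lower number from compound 1 to compound 3 (0.22 log units; within the scatter) and likewise opens no measurable gap, so this position holds the number with either an ether or an amide link. No supporting measurement explains why these groups read alike.

Going by these compounds, how a carboxylic acid or an amine on this chain would read remains open. So does whether a longer chain keeps the number this low.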